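Furan-2-yl in place of 2-chlorophenyl: an expected step

The compounds below may be only part of what the source reports. "The series", "measured", "known", "first", "only" and "open" are said of these compounds alone.

Compound 1 `CC1=CC[C@H](C(C)(C)NC(=S)N/N=C/c2ccccc2O)CC1` gives 10900 nM in a functional assay on HT-29 cells (Homo sapiens) for inhibition, read by sulforhodamine B assay, with a stated time of 48 h; on this read-out lower numbers stand for stronger inhibition of growth and higher numbers for weaker inhibition of growth.
Compound 2 `CC1=CC[C@H](C(C)(C)NC(=S)N/N=C/c2ccc(F)cc2)CC1` reaches only the assay limit, > 100000 nM.
Compound 3 `CC1=CC[C@H](C(C)(C)NC(=S)N/N=C/c2ccccc2Cl)CC1` gives 71300 nM.

Among the compounds with values here, of the two numbers known, compound 3 holds the higher, weaker one, separated from compound 1 by a 6.5-fold higher number from compound 1 to compound 3 (0.82 log units; beyond the scatter). Compound 4 `CC1=CC[C@H](C(C)(C)NC(=S)N/N=C/c2ccco2)CC1` differs from compound 3 by furan-2-yl in place of 2-chlorophenyl on a carbon with a double bond to nitrogen. Within the data shown here, two steps bear on this change. Replacing the hydroxy with chloro gave a 6.5-fold higher number from compound 1 to compound 3 (0.82 log units; beyond the scatter), and moving to a 4-fluorophenyl gave an at least 9.1-fold higher number from compound 1 to compound 2 (0.96 log units; beyond the scatter), where compound 2 sits at the limit (the limit of > 100000 nM in this assay, at which 1 of the 3 values shown sits). Between the two halogenated rings, an at least 1.4-fold lower number from compound 2 to compound 3 (0.14 log units; that floor lies within the scatter) stays within the scatter. The furan-2-yl carries one acceptor but no donor, so a large gain is not expected. For compound 4 the estimate in this assay is 45000 nM, between 12000 nM and 150000 nM, an expected 1.6-fold lower number from compound 3 to compound 4 (0.20 log units; within the scatter).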

Compound 4, concentration for 50% growth inhibition: 7200 nM
For compound 4 the middle estimate is 6.3-fold (0.80 log units) above the measured one; measured number outside the range, below it.
By their numbers in this assay, from the lowest: compounds 4 and 1 (each within the scatter of the next); then compound 3. At a limit, above all of these: compound 2.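

The 2-hydroxyphenyl is not the only ring at this place that keeps the number low: furan-2-yl gives a 1.5-fold lower number from compound 1 to compound 4 (0.18 log units; within the scatter), whereas both halogenated rings gave weaker numbers. Swapping in furan-2-yl for the 2-chlorophenyl gives a 9.9-fold lower number from compound 3 to compound 4 (1.00 log units; beyond the scatter), and for the 4-fluorophenyl it gives an at least 13-fold lower number from compound 2 to compound 4 (1.14 log units; beyond the scatter). That last step is only a floor, since compound 2 stands at a limit and not at a number: the limit of > 100000 nM in this assay, at which 1 of the 4 values shown sits.

From the compounds shown here alone, whether a thiophen-2-yl or a pyridin-2-yl would hold this level remains open. So does whether an amine on the furan-2-yl would change it.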